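The source may hold more compounds than are shown below. What is called first, only, known or untested is meant among the compounds shown, and "the series" means these compounds.

Measured compounds: compound 1 `COC/C1=C/C[C@](C)(CCC=C(C)C)/C=C/[C@@H](OC(=O)C=C(C)C)[C@](C)(OC)/C=C/C1=O` with 4180 nM; compound 2 `CC(C)=CCC[C@]1(C)/C=C/[C@@H](OC(=O)C=C(C)C)[C@](C)(O)/C=C/C(=O)/C(C(=O)O)=C\C1` with > 10000 nM; compound 3 `CC(C)=CCC[C@]1(C)/C=C/[C@@H](OC(=O)C=C(C)C)[C@](C)(O)/C=C/C(=O)/C(C[Si](c2ccccc2)(c2ccccc2)C(C)(C)C)=C\C1` with 13000 nM.

The study reads antiproliferative activity in a functional assay on A549 cells (Homo sapiens) for antiproliferative activity, read by MTT assay, with a stated time of 48 h; on this read-out lower numbers stand for stronger inhibition and higher numbers for weaker inhibition. Compound 1 gives 4180 nM in this assay. Compound 3 gives 13000 nM. For compound 2 the assay reports only a limit, > 10000 nM, so compound 2 stands at the edge of what the read-out can resolve, a point underlined by the limit of > 10000 nM in this assay, at which 1 of the 3 values shown sits.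

The step of interest leads from compound 2 to compound 4 `CO/N=C/C1=C/C[C@](C)(CCC=C(C)C)/C=C/[C@@H](OC(=O)C=C(C)C)[C@](C)(O)/C=C/C1=O`, which has not yet been measured in this assay. The change is a group of 4 heavy atoms (2 carbon, 1 nitrogen, 1 oxygen; no ring) in place of a group of 3 heavy atoms (1 carbon, 2 oxygen; no ring), on a double-bonded ring carbon; the carboxy group leaves and a group with no hydrogen-bond donor enters, on a double-bonded ring carbon of the non-aromatic ring of carbon only. Going by the values given here, since compound 2 offers only a limit, no measured step bounds this change; the expected move in this assay is a gain in inhibition of modest size, so that compound 4 is expected to land in the range of compound 1 rather than at the limit, with the step of an at least 1.6-fold lower number from compound 2 to compound 4 (0.22 log units; that floor lies within the scatter) carrying real uncertainty. Compound 4 is estimated at 6000 nM, between 2500 nM and 20000 nM.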

Compound 4, half-maximal inhibitory concentration: 3470 nM
Beside the measured number, compound 4's estimate is 1.7-fold (0.24 log units) above it; the range from low to high includes it.
By their numbers in this assay, from the lowest: compounds 4 and 1 (each within the scatter of the next); then compound 3.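

In this assay, going by these compounds alone, the earlier compounds offered no measured step at this double-bonded ring carbon. For compound 2, the value > 10000 nM is a limit of the assay and not a number. Even so, setting a group with no hydrogen-bond donor in place of the carboxy group gives an at least 2.8-fold lower number from compound 2 to compound 4 (0.45 log units; beyond the scatter), so this first readable step shows that the position responds to this change, though the step has only a floor and no exact size: the limit of > 10000 nM in this assay, at which 1 of the 4 values shown sits.

The compounds shown do not separate the loss of the carboxy group's hydrogen-bond donor from any other difference between the two groups. Going by these compounds, how an amide or a primary amine on this ring carbon would read in this assay remains open.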